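The source may report more compounds than this note shows. Statements on the series, on what has been measured and on what is new or still open speak of the compounds shown alone.

Compound 1 `COc1ccccc1/C=C(\C(=O)c1ccc(Cl)cc1)S(=O)(=O)Cc1ccc(Cl)c(Cl)c1`: 1000 nM
Compound 2 `COc1ccccc1/C=C(\C(=O)c1ccc(Cl)cc1)S(=O)(=O)c1ccc(C)cc1`: 1000 nM
Compound 3 `CCOc1ccc(/C=C(/Sc2ccc(C)cc2)C(=O)c2ccc(Cl)cc2)cc1OC`: 25000 nM

All three measured compounds were run in a functional assay on DU-145 cells (Homo sapiens) for inhibition, read by trypan blue exclusion, with a stated time of 96 h; on this read-out higher numbers stand for weaker inhibition of growth and lower numbers for stronger inhibition of growth. Compound 2 and compound 1 differ in one place: 3,4-dichlorobenzyl in place of 4-methylphenyl on a sulfonyl sulfur. That change left the read-out where it was, as no change at the digits printed from compound 2 to compound 1 (within the scatter) shows. Compound 3 sits on a different core; how the core of compound 3 differs from the core of compound 2 is not broken down here, so the two are tied only by their values, and in this assay compound 3 gives 25000 nM, the highest number of the three.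

Compound 4 `CCOc1ccc(/C=C(/SCc2ccc(Cl)c(Cl)c2)C(=O)c2ccc(Cl)cc2)cc1OC` has not yet been measured. It arises from compound 3 by 3,4-dichlorobenzyl in place of 4-methylphenyl on a sulfur. For the measured compounds named here, this is the same kind of change as the one from compound 2 to compound 1, not the same change: there the place was a sulfonyl sulfur whose other neighbours are a double-bonded chain carbon, here it is a sulfur whose other neighbours are a double-bonded chain carbon. One earlier instance of the change is known, and it moved nothing.

Compound 4 is therefore expected to stay close to compound 3, with an expected step of no change at the digits printed from compound 3 to compound 4 (within the scatter), because no change at the digits printed from compound 2 to compound 1 (within the scatter) gives no sign that the change moves the read-out. Compound 4 is estimated at 25000 nM in this assay, with the expected range running from 8000 nM to 70000 nM.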

Compound 4, concentration for 50% growth inhibition: 25000 nM
Estimate against measurement, compound 4: no gap at the digits printed; measured number inside the range.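

In this assay, putting 3,4-dichlorobenzyl in place of 4-methylphenyl on a sulfur gives no change at the digits printed from compound 3 to compound 4 (within the scatter). Set beside the earlier case on a sulfonyl sulfur, the same exchange leaves the read-out in place on both cores, and the two steps do not differ: the same change on two cores in this assay, no change at the digits printed (within the scatter) from compound 2 to compound 1 and no change at the digits printed (within the scatter) from compound 3 to compound 4, 1.0-fold (0.00 log units) apart, within the scatter of two such steps. These are only two instances, so they show that this one exchange carried over between these two cores without a visible effect, but they do not show that it would do so on a third core, and they do not explain why the read-out stays where it is.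

The compounds shown leave open whether a different group on the sulfur, such as a longer chain, an amine or a carboxylic acid, would move the read-out on either core. They also leave open which of the several differences between the core of compound 2 and the core of compound 3 goes with the gap between their values, since no pair shown changes the sulfonyl sulfur alone or the ring ethers alone.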